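The source may report more compounds than this note shows. Statements on the series, on what has been measured and on what is new or still open speak of the compounds shown alone.

Measured so far in a functional assay on KM12 cells (Homo sapiens) for inhibition, read by sulforhodamine B assay, with a stated time of 48 h, tested at 10 uM; a higher number here means more inhibition at the concentration tested (going by the name of the read-out), a lower number less inhibition:
compound 1, `Fc1ccc(-c2cn3ccnc3c(-c3ccc4ncn(C5CCCCC5)c4c3)n2)cc1`: 3.49%
compound 2, `Clc1ccc(-c2cn3ccnc3c(-c3ccc4ncn(C5CCCCC5)c4c3)n2)cc1`: 10.6%

Within the data shown here, compound 2 is one of two compounds with a number in this assay; its nearest neighbour is compound 1, and the only step between them, a number 7.1 percentage points higher from compound 1 to compound 2 (within the scatter), separates the two by no more than repeated runs of the same kind would. Compound 2 therefore stands at a low level of inhibition, not distinguishable from compound 1.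

Compound 3, `COc1ccccc1-c1cn2ccnc2c(-c2ccc3ncn(C4CCCCC4)c3c2)n1`, has not yet been measured. It differs from compound 2 at one site: 2-methoxyphenyl in place of 4-chlorophenyl on an aromatic carbon. No measured step touches this group; the one step shown, from compound 1 to compound 2, swaps one halogen for another on the same ring and lies within the scatter. There is thus no basis for expecting a step beyond the scatter in this assay in either direction. Compound 3 is expected to stay near the level of compound 2, a change of a number 2.6 percentage points lower from compound 2 to compound 3 (within the scatter), giving an estimate of 8%, with a range from -5% to 25%.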

Compound 3, a percentage reported as inhibition, at one concentration (the size of the read-out at that concentration, not a potency): 3.58%
Estimate against measurement, compound 3: 4.4 percentage points above; the range from low to high includes it.
By their numbers in this assay, from the lowest: compounds 1, 3 and 2 (each within the scatter of the next).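

In this assay, 2-methoxyphenyl in place of 4-chlorophenyl gives a number 7 percentage points lower from compound 2 to compound 3 (within the scatter) and 2-methoxyphenyl in place of 4-fluorophenyl gives a number 0.1 percentage points higher from compound 1 to compound 3 (within the scatter) at this aromatic carbon next to the ring nitrogen. The position has therefore now taken a change of substituent type and of its place on the phenyl ring, not only an exchange of one halogen for another, without any step beyond the scatter. Nothing available bears on why these aryl exchanges give no separation.

Open, as far as these compounds go, is whether a phenyl ring carrying an amine or a carboxylic acid, or a morpholine in place of the aryl group, would move the reading in this assay beyond the scatter. Also open, from the compounds shown here alone, is whether any change elsewhere on the shared core would do so.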